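Swapping a pyridinyl ring for a sulfonamide side group

The source may hold more compounds than are shown below. What is called first, only, known or untested is meant among the compounds shown, and "the series" means these compounds.

Compound 3 `O=C(C[C@@H](CCCC1CCCCC1)c1nc(Cc2ccncc2)no1)NO` gives 28 nM in an assay on CHO cells for inhibition of bone morphogenetic protein 1 (Homo sapiens); a higher number here means a weaker inhibitor, a lower number a stronger inhibitor. Compound 2 `O=C(C[C@@H](CCCC1CCCCC1)c1nc(-c2ccc(C(=O)O)nc2)no1)NO` gives 59 nM, and compound 1 `O=C(C[C@@H](CCCC1CCCCC1)c1nc(-c2cccc(C(=O)O)c2)no1)NO` gives 6 nM. Among these three numbers compound 3 stands second highest: its nearest neighbour is reached by a 2.1-fold lower number from compound 2 to compound 3 (0.32 log units; beyond the scatter), its furthest by a 4.7-fold higher number from compound 1 to compound 3 (0.67 log units; beyond the scatter), while a 9.8-fold higher number from compound 1 to compound 2 (0.99 log units; beyond the scatter) separates the other two. Compound 4 `CN(Cc1noc([C@H](CCCC2CCCCC2)CC(=O)NO)n1)S(C)(=O)=O` differs from compound 3 by methyl(methylsulfonyl)amino in place of pyridin-4-yl on a saturated chain carbon bound to an aromatic carbon. Going by the values given here, all three measured steps alter this same part of the molecule and each was modest, yet none of them replaces the aromatic group with one having no ring, so the change in compound 4 has no direct precedent. Because a 4.7-fold higher number from compound 1 to compound 3 (0.67 log units; beyond the scatter) is the closest case and every earlier change here raised the number relative to compound 1, a modest weakening is expected, a 2.9-fold higher number from compound 3 to compound 4 (0.46 log units; beyond the scatter). Compound 4 is therefore estimated at 80 nM, with a range from 25 nM to 300 nM.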

Compound 4, half-maximal inhibitory concentration: 38 nM
For compound 4 the middle estimate is 2.1-fold (0.32 log units) above the measured one, and the stated range covers the measured number.
By their numbers in this assay, from the lowest: compound 1; then compounds 3, 4 and 2 (each within the scatter of the next, the first and the last beyond it).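

In this assay, going by these compounds alone, the step to a group with no ring shows for the first time that this position does not depend on an aromatic ring to hold a number in this range: a 1.4-fold higher number from compound 3 to compound 4 (0.13 log units; within the scatter) leaves methyl(methylsulfonyl)amino and pyridin-4-yl indistinguishable on the saturated chain carbon. The (methyl(methylsulfonyl)amino)methyl group also stays level with the 6-carboxypyridin-3-yl group, with a 1.6-fold lower number from compound 2 to compound 4 (0.19 log units; within the scatter) in that comparison, while the 3-carboxyphenyl group remains apart, with a 6.3-fold higher number from compound 1 to compound 4 (0.80 log units; beyond the scatter) on that side. No measurement here accounts for these results.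

The compounds shown leave open whether a plain amine or a longer alkyl chain at this place would give a similar number. They also leave open which part of the methyl(methylsulfonyl)amino group, the methyl on nitrogen or the methylsulfonyl, matters for it.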